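From 2,3-dihydroxyphenyl to 3-(trifluoromethyl)phenyl: an expected loss

The compounds below may be only part of what the source reports. "The series", "measured", "known", "first", "only" and "open" are said of these compounds alone.

In a functional assay on G-361 cells (Homo sapiens) for antiproliferative activity, with a stated time of 72 h (a higher number here means a weaker inhibitor, a lower number a stronger inhibitor), compound 3 `OC[C@H]1O[C@@H](n2cnc3c(NCc4cccc(O)c4O)ncnc32)[C@H](O)[C@@H]1O` gives 16900 nM, the lowest of the two actual numbers. Compound 2 `OC[C@H]1O[C@@H](n2cnc3c(NCc4ccc(Cl)cc4Cl)ncnc32)[C@H](O)[C@@H]1O` gives 128000 nM. Compound 1 `OC[C@H]1O[C@@H](n2cnc3c(NCc4cccc(Br)c4)ncnc32)[C@H](O)[C@@H]1O` reads > 166000 nM, which is a limit of the assay and not a number.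

Compound 4 `OC[C@H]1O[C@@H](n2cnc3c(NCc4cccc(C(F)(F)F)c4)ncnc32)[C@H](O)[C@@H]1O` departs from compound 3 by one change: 3-(trifluoromethyl)phenyl in place of 2,3-dihydroxyphenyl on a saturated chain carbon bound to a nitrogen on an aromatic ring.

For the measured compounds named here, two measured steps bear on it, an at least 9.8-fold lower number from compound 1 to compound 3 (0.99 log units; beyond the scatter) and a 7.6-fold lower number from compound 2 to compound 3 (0.88 log units; beyond the scatter). Both favour 2,3-dihydroxyphenyl over the halogenated groups, while an at least 1.2-fold lower number from compound 1 to compound 2 (0.11 log units; that floor lies within the scatter) separates those groups by no more than the scatter. Reversing that gain, a higher number of similar size is expected in this assay. The expected step is a 7.7-fold higher number from compound 3 to compound 4 (0.89 log units; beyond the scatter). For compound 4 the estimate is 130000 nM, with an expected range of 50000 nM to 300000 nM.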

Compound 4, half-maximal inhibitory concentration: > 166000 nM
Compound 4 gave a limit, no number; the forecaster's own chance of this, stated with the estimate: 50%; middle value at least 1.2-fold (0.10 log units) from the limit.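

In this assay, compound 4 gives only a limit, > 166000 nM, not a number. The change gives an at least 9.8-fold higher number from compound 3 to compound 4 (0.99 log units; beyond the scatter), so a third halogen-bearing group at this place, now with fluorine and no hydrogen-bond donors, also falls short of 2,3-dihydroxyphenyl, while an at least 1.2-fold higher number from compound 2 to compound 4 (0.11 log units; that floor lies within the scatter) does not separate it from 2,4-dichlorophenyl. The step between compound 1 and compound 4 cannot be read: the limit of > 166000 nM in this assay, at which 2 of the 4 values shown sit.

Open, on these data alone, is whether both hydroxyl groups are needed, or whether a single hydroxyl would hold the level of compound 3. Also open, as far as these compounds go, is how a methoxy, an amine or a carboxylic acid on the phenyl ring would read.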